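A few compounds are considered here, and "the series" means these few. Any claim that something is new, unique, unknown or untested is made for them only; others in the source may bear on it.

In a physicochemical assay for solubility, at pH 7.4 (a higher number here means a more soluble compound, a lower number a less soluble compound), compound 1 (`Cc1cc(NC(=O)Nc2ccccc2OC(F)(F)F)c2ccccc2n1`) gives 4600 nM, the higher of the two numbers in hand. Compound 2 (`CSc1ccc(NC(=O)Nc2cc(C)nc3ccccc23)cc1`) gives 1300 nM, lower by more than the scatter. For the measured compounds named here, these two compounds differ in more than one place, so no single-change step is available as a guide. Compound 3 (`Cc1cc(NC(=O)Nc2ccccc2C(C)(C)C)c2ccccc2n1`) has tert-butyl in place of trifluoromethoxy on an aromatic carbon, ortho to a large group: tert-butyl in place of trifluoromethoxy on an aromatic carbon. A small downward move in this assay, probably within the scatter, is expected. The estimated move is a 1.5-fold lower number from compound 1 to compound 3 (0.19 log units; within the scatter). Compound 3 is estimated at 3000 nM, with an expected range of 1000 nM to 9000 nM.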

Compound 3, solubility: 100 nM
Compound 3: middle estimate off by 30-fold (1.48 log units), on the high side; the measured number lies below the stated range.
By their numbers in this assay, from the lowest: compound 3; then compound 2; then compound 1.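

On an aromatic carbon ortho to a large group, tert-butyl in place of trifluoromethoxy is far from neutral in this assay and gives a large step (a 46-fold lower number from compound 1 to compound 3 (1.66 log units; beyond the scatter)). This shows that a change at this one place on the shared core can by itself move the number well beyond the scatter, which compound 1 and compound 2 could not show. No measurement in hand accounts for the size of this step.

Open, from the compounds shown here alone, is whether a methyl group, an amine or a carboxylic acid at this place would read closer to compound 1 or to compound 3. Also open, going by these compounds, is whether the step holds with the same change at another ring position.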